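The source may report more compounds than this note shows. Statements on the series, on what has been measured and on what is new or still open speak of the compounds shown alone.

Three compounds have been measured in a functional assay on THP-1 cells (Homo sapiens) for inhibition, read by sulforhodamine B assay, with a stated time of 48 h, tested at 50 uM; a higher number here means more inhibition of growth at the concentration tested, a lower number less inhibition of growth:

Compound 1, `COc1cc(/C=C/C(=O)/C=C/c2cccc3ccccc23)ccc1OCc1cn(CCCOc2cc(=O)oc3ccccc23)nn1`, gives 71%.
Compound 2, `COc1cc(/C=C/C(=O)/C=C/c2ccco2)ccc1OCc1cn(CCCOc2cc(=O)oc3ccccc23)nn1`, gives 57%.
Compound 3, `COc1cc(/C=C/C(=O)/C=C/c2cccc3ccccc23)ccc1OCc1cn(CCCCOc2cc(=O)oc3ccccc23)nn1`, gives 54%.

Compound 1 and compound 2 share one core and differ in a single place: furan-2-yl in place of naphthalen-1-yl on a double-bonded chain carbon bound to a double-bonded chain carbon. This change carries a step of a number 14 percentage points lower from compound 1 to compound 2 (beyond the scatter), so compound 2 sits clearly under compound 1 in this assay.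

Compound 3 carries the same naphthalen-1-yl group as compound 1 but rests on a different core; how the two cores differ is not broken down here. Its value is the lowest of the three, with compound 2 within the usual scatter of it and compound 1 beyond it.

Compound 4, `COc1cc(/C=C/C(=O)/C=C/c2ccco2)ccc1OCc1cn(CCCCOc2cc(=O)oc3ccccc23)nn1`, has not yet been measured. It is made from compound 3 by furan-2-yl in place of naphthalen-1-yl on a double-bonded chain carbon bound to a double-bonded chain carbon, the same change that leads from compound 1 to compound 2. Going by the values given here, since the one measured example of this change gave a number 14 percentage points lower from compound 1 to compound 2 (beyond the scatter), a step of similar size is expected here, and the estimated step from compound 3 to compound 4 is a number 14 percentage points lower from compound 3 to compound 4 (beyond the scatter). On that basis compound 4 is expected to give about 40% in this assay, with the range from 26% to 54% taken as likely; how far the second core carries this change is not known from the three compounds measured.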

Compound 4, percent growth inhibition at one concentration: 49%
Beside the measured number, compound 4's estimate is 9 percentage points below it, and the stated range covers the measured number.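

In this assay, placing furan-2-yl where naphthalen-1-yl stood on the core of compound 3 gives a number 5 percentage points lower from compound 3 to compound 4 (within the scatter), and this step cannot be told apart from the one seen on the core of compound 1: the same change on two cores in this assay, a number 14 percentage points lower (beyond the scatter) from compound 1 to compound 2 and a number 5 percentage points lower (within the scatter) from compound 3 to compound 4, 9 percentage points apart, within the scatter of two such steps. Going by these compounds alone, the exchange can therefore be read across these two cores as one step of no demonstrably different size, with the caveat that only the step on the core of compound 1 lies beyond the scatter, while the step on the other core does not by itself separate compound 4 from compound 3. Two pairs do not show that the exchange would behave alike on any further core, and they neither prove that the two steps are equal nor explain why their printed sizes are not identical.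

The compounds shown leave open how other groups would behave on a double-bonded chain carbon bound to a double-bonded chain carbon, such as a phenyl ring, a pyridine ring or a ring bearing an amine or a carboxylic acid. They also leave open whether the exchange would give a comparable step on a core with a longer chain.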